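Moving the nitrile on the benzyl ring of compound 3

This account rests on a few compounds, and the source may have more. Where it says the series, first, only, none or still open, it means among the compounds named here.

Compound 1, `Cc1ccc(Cn2cc(COc3ccc4c(=O)ccoc4c3)nn2)cc1`, in an ADME assay on L02 cells (Homo sapiens) for cytotoxicity, read by MTT assay, with a stated time of 48 h (on this read-out lower numbers stand for stronger inhibition and higher numbers for weaker inhibition), gives > 300000 nM, which is a limit of the assay.
Compound 2, `O=c1ccoc2cc(OCc3cn(Cc4ccc(F)cc4)nn3)ccc12`, in this assay gives > 300000 nM, again a limit of the assay.
Compound 3, `N#Cc1ccc(Cn2cc(COc3ccc4c(=O)ccoc4c3)nn2)cc1`, in this assay gives > 300000 nM, also a limit of the assay.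

Compound 3 therefore stands at a limit, and the two further values shown are limits as well, so no number places it among them. The three steps between the measured compounds, a step that the two limits leave unreadable from compound 1 to compound 2, a step that the two limits leave unreadable from compound 1 to compound 3 and a step that the two limits leave unreadable from compound 2 to compound 3, all remain unreadable in size because of the limit of > 300000 nM in this assay, at which 3 of the 3 values shown sit.

Compound 4, `N#Cc1cccc(Cn2cc(COc3ccc4c(=O)ccoc4c3)nn2)c1`, differs from compound 3 by 3-cyanophenyl in place of 4-cyanophenyl on a saturated chain carbon bound to an aromatic nitrogen. The measured steps bear on it only in that none of them moved any compound off the limit; they give no direction and no size. The expected step in this assay is a number no higher from compound 3 to compound 4 (the limit leaves the size open), that is, none beyond the scatter. Compound 4 is accordingly estimated to give 300000 nM, most likely reported as a limit, with a range from 100000 nM to 1000000 nM.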

Compound 4, half-maximal inhibitory concentration: > 300000 nM
Compound 4 gave a limit, no number (the forecaster's own chance of this, stated with the estimate: 85%); the middle value sits exactly at the limit.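

Moving the nitrile from 4-cyanophenyl in compound 3 to 3-cyanophenyl in compound 4 yields no readable step, and neither do the steps from compound 1 or compound 2 to compound 4, because all four compounds rest at one limit: the limit of > 300000 nM in this assay, at which 4 of the 4 values shown sit.

The compounds shown leave open whether in this assay the 3-cyanophenyl and 4-cyanophenyl groups differ at all.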